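This account rests on a few compounds, and the source may have more. Where it says the series, first, only, none or still open, it means among the compounds named here.

Measured compounds:
compound 1 `CCOC(=O)c1ccc(-c2nn(C)c3ccccc23)cc1` — 270 nM
compound 2 `CCOC(=O)c1ccc(-c2nn(Cc3ccccc3F)c3ccccc23)cc1` — 110 nM
compound 3 `COC(=O)c1ccc(-c2nn(Cc3ccccc3)c3ccccc23)cc1` — 560 nM

In a functional assay on cells (Platelet, Homo sapiens) for inhibition (on this read-out lower numbers stand for stronger inhibition and higher numbers for weaker inhibition), compound 3 gives the highest of the three numbers; compound 1 stands nearest to it and compound 2 furthest, both with lower numbers and both gaps beyond the scatter. Among the measured compounds shown here, compound 1 and compound 3 differ in two places at once, so their two values show only that compound 3 lies above compound 1.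

Compound 4 `CCOC(=O)/C=C/c1ccc(-c2nn(Cc3ccccc3)c3ccccc23)cc1` is the unmeasured member. It differs from compound 3 in one place: 2-(ethoxycarbonyl)ethenyl in place of methoxycarbonyl on an aromatic carbon.

For the measured compounds named here, the only single-place step so far, a 2.5-fold lower number from compound 1 to compound 2 (0.39 log units; beyond the scatter), concerns a different part of the molecule and says nothing direct about exchanging the ester group. Going by the values given here, no measured pair alters the group on the carbon-only ring. Among the compounds with values here, the expectation for compound 4 therefore rests on no precedent and must stay wide: the change is expected to give a step of a 1.1-fold lower number from compound 3 to compound 4 (0.05 log units; within the scatter) in this assay, which is about none beyond the scatter.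

Compound 4 is estimated at 500 nM in this assay, with a range from 150 nM to 1800 nM.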

Compound 4, half-maximal inhibitory concentration: > 10000 nM
Compound 4 ended at the assay's limit (the forecaster's own chance of this, stated with the estimate: 5%); middle value at least 20-fold (1.30 log units) from the limit.
By their numbers in this assay, from the lowest: compound 2; then compound 1; then compound 3. At a limit, above all of these: compound 4.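

In this assay the group on the aromatic carbon para to a large group turns out to matter strongly: 2-(ethoxycarbonyl)ethenyl in place of methoxycarbonyl gives an at least 17-fold higher number from compound 3 to compound 4 (1.25 log units; beyond the scatter). Compound 4 gives > 10000 nM, which is a limit of the assay and not a number. Keeping an ester on this carbon is therefore not enough to keep inhibition, and the true size of the step stays unknown: the limit of > 10000 nM in this assay, at which 1 of the 4 values shown sits.

Open, on these data alone, is whether the ethenyl link, the ethyl ester or the two together account for the step, as compound 4 carries both in one change. The compounds shown also leave open how a carboxylic acid, an amide or a saturated chain bearing the same ester would read on this carbon, and whether a 2-fluorophenyl group on the ring nitrogen's chain would alter the outcome.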